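The source may hold more compounds than are shown below. What is called first, only, known or untested is meant among the compounds shown, and "the series" means these compounds.

Values measured in a functional assay on A549 cells (Homo sapiens) for antiproliferative activity, read by MTT assay, with a stated time of 48 h (on this read-out higher numbers stand for weaker inhibition and lower numbers for stronger inhibition), are as follows

Compound 1 `COc1ccc2nc(NC(c3cn(-c4ccccc4)nc3-c3ccc(Cl)cc3)c3c(O)ccc4ccccc34)sc2c1` gives 34500 nM
Compound 2 `O=[N+]([O-])c1cccc(-c2nn(-c3ccccc3)cc2C(Nc2nc3ccc(Cl)cc3s2)c2c(O)ccc3ccccc23)c1` gives 42500 nM
Compound 3 `COc1cccc(-c2nn(-c3ccccc3)cc2C(Nc2nc3ccc(Cl)cc3s2)c2c(O)ccc3ccccc23)c1` gives 49800 nM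

Compound 3 at 49800 nM lies within the scatter of both compound 1 and compound 2, so the three values cannot be ranked. The next compound is compound 4 `Oc1ccc2ccccc2c1C(Nc1nc2ccc(Cl)cc2s1)c1cn(-c2ccccc2)nc1-c1ccc(Cl)cc1` and its difference from compound 3 is 4-chlorophenyl in place of 3-methoxyphenyl on an aromatic carbon with 4-chlorophenyl in place of 3-methoxyphenyl on an aromatic carbon. Among the measured compounds shown here, one measured step bears on this place. It is a 1.2-fold higher number from compound 2 to compound 3 (0.07 log units; within the scatter) and it stays within the scatter. Compound 4 also shares the 4-chlorophenyl with compound 1, which differs from it elsewhere in the core, and compound 1 gives 34500 nM in the same narrow band. No step beyond the scatter is therefore expected in this assay and no direction can be called. The estimated change is a 1.2-fold lower number from compound 3 to compound 4 (0.10 log units; within the scatter) and is expected to stay within the scatter. Compound 4 is estimated at 40000 nM and expected to fall between 20000 nM and 80000 nM on measurement.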

Compound 4, half-maximal inhibitory concentration: 54100 nM
Estimate against measurement, compound 4: 1.4-fold (0.13 log units) below, and the stated range covers the measured number.
By their numbers in this assay, from the lowest: compounds 1, 2, 3 and 4 (each within the scatter of the next).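

In this assay, this aromatic carbon of the five-membered ring now carries three different aryl groups without the number leaving one narrow band: 4-chlorophenyl in place of 3-methoxyphenyl gives a 1.1-fold higher number from compound 3 to compound 4 (0.04 log units; within the scatter) and 4-chlorophenyl in place of 3-nitrophenyl gives a 1.3-fold higher number from compound 2 to compound 4 (0.10 log units; within the scatter). The change in the shared core, chloro in place of methoxy with the 4-chlorophenyl kept, gives a 1.6-fold higher number from compound 1 to compound 4 (0.20 log units; within the scatter), so neither place has yet produced a step beyond the scatter. No measurement is available that would explain this flat result.

It remains open whether any group on this carbon can move the number beyond the scatter at all, since all three groups shown are substituted phenyl rings. A phenyl ring bearing an amine or a carboxylic acid, or a longer chain in place of the ring, would put that to the test.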